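Swapping a Bromo for a Methylpiperazine on the Thiazole

A few compounds are considered here, and "the series" means these few. Any claim that something is new, unique, unknown or untested is made for them only; others in the source may bear on it.

Among the three compounds with numbers, compound 3 `CC(C)(C)[C@H](C(=O)Nc1ncc(Br)s1)c1ccc(Cl)cc1` gives the lowest one: in a functional assay on CHO cells for agonist activity at Free fatty acid receptor 2 (Homo sapiens), read by cAMP accumulation (a lower number here means a stronger inhibitor, a higher number a weaker inhibitor), compound 3 gives 700 nM, whereas compound 2 `CC(C)[C@H](C(=O)Nc1nc(C(C)(C)C)cs1)c1ccc(Cl)cc1` gives 7900 nM and compound 1 `CC(C)[C@H](C(=O)Nc1nc(C(F)(F)F)cs1)c1ccc(Cl)cc1` gives 17000 nM. Compound 4 `CN1CCN(c2cnc(NC(=O)[C@H](c3ccc(Cl)cc3)C(C)(C)C)s2)CC1` differs from compound 3 in one place: 4-methylpiperazin-1-yl in place of bromo on an aromatic carbon. Among the measured compounds shown here, the only measured single step, a 2.2-fold lower number from compound 1 to compound 2 (0.33 log units; beyond the scatter), concerns a different carbon of the same five-membered ring and is modest; no measured step exchanges the bromo or introduces a group of this kind, so nothing here directly bears on the change. A step beyond the scatter in either direction is therefore possible, with a weaker result somewhat more likely; the expected step is a 3.6-fold higher number from compound 3 to compound 4 (0.55 log units; beyond the scatter), and compound 4 is estimated at 2500 nM, within a range from 400 nM to 15000 nM.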

Compound 4, half-maximal inhibitory concentration: 3800 nM
Compound 4: the middle estimate sits 1.5-fold (0.18 log units) below what was measured; measured number inside the range.
By their numbers in this assay, from the lowest: compound 3; then compound 4; then compound 2; then compound 1.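

At this carbon, next to the ring sulfur, a single bromine can give way to the much larger 4-methylpiperazin-1-yl group, with its six-membered non-aromatic ring, at a modest cost: in this assay the change brings a 5.4-fold higher number from compound 3 to compound 4 (0.73 log units; beyond the scatter). The activity therefore weakens but is not lost. Nothing available explains the size of this step. On these data alone, it remains open whether the step reflects losing bromo or adding the piperazine. A plain hydrogen, a methyl or a morpholine at this carbon would help separate the two.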